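The source may hold more compounds than are shown below. What is called first, only, known or untested is meant among the compounds shown, and "the series" means these compounds.

Of the compounds shown here, two on the shared core have numbers so far. In a functional assay on HepG2 cells (Homo sapiens) for inhibition, read by MTT assay, with a stated time of 48 h (a lower number here means a stronger inhibitor, a higher number a weaker inhibitor), compound 1 `CCOC(=O)C1=C(N/C=N/c2nnc(S(N)(=O)=O)s2)Nc2[nH]nc(C)c2C1c1ccc(N(C)C)cc1` gives 38100 nM, while compound 2 `CCOC(=O)C1=C(NN=C(C#N)C#N)Nc2[nH]nc(C)c2C1c1ccc(N(C)C)cc1` gives 13700 nM, the lower of the two numbers, with the gap beyond the scatter. The next compound is compound 3 `CCOC(=O)C1=C(N/N=C(/Cl)c2ccc([N+](=O)[O-])cc2)Nc2[nH]nc(C)c2C1c1ccc(N(C)C)cc1`, and its change from compound 2 is a group of 12 heavy atoms (7 carbon, 2 nitrogen, 2 oxygen, 1 chlorine; one six-membered aromatic ring of carbon only) in place of a group of 6 heavy atoms (3 carbon, 3 nitrogen; no ring), on an amine nitrogen. The group that leaves has no ring, and the group that enters carries one six-membered aromatic ring of carbon only.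

Among the compounds with values here, only one measured step bears on this change, at the same kind of amine nitrogen: a 2.8-fold lower number from compound 1 to compound 2 (0.44 log units; beyond the scatter), modest in size. In that step a larger group with a ring gave way to the smaller group without one, and the number fell. Compound 3 goes the opposite way in size and ring content, though with a different ring, so this single step is weak guidance. A small move to a higher number in this assay is expected, no larger than that modest step. The estimated change is a 1.8-fold higher number from compound 2 to compound 3 (0.24 log units; within the scatter). For compound 3 the estimate is 24000 nM, with an expected range from 8000 nM to 70000 nM.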

Compound 3, half-maximal inhibitory concentration: 55500 nM
Compound 3: the middle estimate sits 2.3-fold (0.36 log units) below what was measured, within the range that was stated.
By their numbers in this assay, from the lowest: compound 2; then compounds 1 and 3 (each within the scatter of the next).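

In this assay the swap of the ring-free group for the one carrying a six-membered aromatic ring of carbon only gives a 4.1-fold higher number from compound 2 to compound 3 (0.61 log units; beyond the scatter) and so runs opposite in direction to a 2.8-fold lower number from compound 1 to compound 2 (0.44 log units; beyond the scatter) at the same amine nitrogen. The two ring-bearing groups are not separated, since the change between them is a 1.5-fold higher number from compound 1 to compound 3 (0.16 log units; within the scatter) and stays within the scatter even though one holds a five-membered aromatic ring with 3 hetero atoms and the other a six-membered aromatic ring of carbon only. Compound 2 therefore holds the lowest number of the three, and no compound shown goes against the reading that the ring-free group is the one set apart at this position, though that reading rests on compound 2 alone. Nothing measured here explains these differences.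

Going by these compounds, with a single ring-free group in hand, it remains open whether the absence of a ring or something else particular to that group sets compound 2 apart. A short alkyl chain or a carboxylic acid on the same amine nitrogen would test whether another ring-free group also gives a number near that of compound 2.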